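Chain Length and Acyl Group in a Cytotoxicity Series

The source may hold more compounds than are shown below. What is called first, only, known or untested is meant among the compounds shown, and "the series" means these compounds.

Measured compounds:
Compound 1, `CCCCCCCCCCCCNC(=O)[C@@H](NC(=O)/C=C/c1ccccc1)[C@@H](C)O`: > 200000 nM
Compound 2, `C/C=C/C=C/C(=O)N[C@H](C(=O)NCCCCCCCCCCCC)[C@@H](C)O`: > 400000 nM
Compound 3, `CCCCCCCCCCCCCCNC(=O)[C@@H](NC(=O)/C=C/c1ccccc1)[C@@H](C)O`: 150000 nM

The three compounds were tested in a functional assay on HepG2 cells (Homo sapiens) for cytotoxicity, read by MTT assay, with a stated time of 48 h; on this read-out higher numbers stand for weaker inhibition and lower numbers for stronger inhibition. In this assay compound 1 reaches only a limit, > 200000 nM, so no number is known for it. Compound 2 likewise gives only a limit, > 400000 nM. Among the measured compounds shown here, compound 3 is the one compound with a number, 150000 nM.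

Compound 2 arises from compound 1 by prop-1-en-1-yl in place of phenyl on a double-bonded chain carbon bound to a double-bonded chain carbon. The step that the two limits leave unreadable from compound 1 to compound 2, as both ends are limits, the limit of > 200000 nM in this assay, at which 1 of the 3 values shown sits, and (the limit of > 400000 nM in this assay, at which 1 of the 3 values shown sits). Compound 3 arises from compound 1 by ethyl in place of hydrogen on a saturated chain carbon, ten or more bonds along the chain from an amide-type nitrogen, and the step is an at least 1.3-fold lower number from compound 1 to compound 3 (0.12 log units; that floor lies within the scatter).

Compound 4, `C/C=C/C=C/C(=O)N[C@H](C(=O)NCCCCCCCCCCCCCC)[C@@H](C)O`, has not been measured. It differs from compound 3 by prop-1-en-1-yl in place of phenyl on a double-bonded chain carbon bound to a double-bonded chain carbon, the same change as that from compound 1 to compound 2, made on the core of compound 3 rather than that of compound 1; the two cores differ by ethyl in place of hydrogen on a saturated chain carbon, ten or more bonds along the chain from an amide-type nitrogen.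

The earlier instance of the change gives no readable size, and compound 2 sits at a limit, so the expectation for compound 4 rests on the weak numbers of the whole set. Compound 4 is expected to give 300000 nM, between 120000 nM and 800000 nM, because compound 2 stands at > 400000 nM and compound 3 at 150000 nM. This means an expected step of a 2.0-fold higher number from compound 3 to compound 4 (0.30 log units; within the scatter), with a good chance that only a limit is reported.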

Compound 4, half-maximal inhibitory concentration: > 400000 nM
Compound 4: a limit, no number (the forecaster's own chance of this, stated with the estimate: 60%); at least 1.3-fold (0.12 log units) between middle value and limit.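

In this assay, putting prop-1-en-1-yl in place of phenyl, on a double-bonded chain carbon bound to a double-bonded chain carbon, gives an at least 2.6-fold higher number from compound 3 to compound 4 (0.42 log units; beyond the scatter); one end of this step is a limit, so its size is a floor and not a measured difference. Among the compounds shown here, this is the only reading of the change, and it points towards weaker inhibition on this one core, while the steps with a limit at both ends cannot be read, so the earlier instance offers no size to set beside it and nothing shows whether the change carries from one core to the other with the same size. Compound 4 gives a limit and no number, and compound 2 stands at that same limit: the limit of > 400000 nM in this assay, at which 2 of the 4 values shown sit.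

The compounds shown leave open how a longer chain on the amide nitrogen would read in this assay, and whether the prop-1-en-1-yl series would then give a number rather than a limit. They also leave open how an amine or a carboxylic acid on the phenyl ring would read there, since only phenyl and prop-1-en-1-yl appear at this place.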